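This account rests on a few compounds, and the source may have more. Where it says the series, first, only, none or still open, it means among the compounds named here.

In an in vivo ADME assay on the whole organism (strain Sprague-Dawley) for pharmacokinetics, with Rattus norvegicus as the target, at a dose of 2 mg/kg by the oral route (a lower number here means that a smaller share of the oral dose reaches the circulation, a higher number that a larger share of the oral dose reaches the circulation), compound 2 (`Cc1cc(C(C)CC(=O)O)ccc1-c1noc(-c2ccc(OC(C)C)c(C(F)(F)F)c2)n1`) gives 100%, the highest of the three numbers, ahead of compound 3 (`Cc1cc([C@H]2C[C@H]2C(=O)O)ccc1-c1noc(-c2ccc(OC(C)C)c(C#N)c2)n1`) at 89% and compound 1 (`Cc1cc(CCC(=O)O)ccc1-c1noc(-c2ccc(OC(C)C)c(C#N)c2)n1`) at 53%. Compound 4 (`Cc1cc(CCC(=O)O)ccc1-c1noc(-c2ccc(OC(C)C)c(C(F)(F)F)c2)n1`) differs from compound 2 by hydrogen in place of methyl on a saturated chain carbon bound to an aromatic carbon and a saturated chain carbon. Going by the values given here, no measured step isolates this change. The closest evidence is another change at the same chain, a number 36 percentage points higher from compound 1 to compound 3 (beyond the scatter), which is large. Compound 4 shares its 2-carboxyethyl with compound 1, at 53%. A large fall is therefore expected, the estimated change being a number 35 percentage points lower from compound 2 to compound 4 (beyond the scatter). The estimate for compound 4 is 65%, with an expected range from 42% to 90%.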

Compound 4, oral bioavailability: 88%
The estimate for compound 4 lay 23 percentage points below the measured number; the measured number falls inside the stated range.
By their numbers in this assay, from the lowest: compound 1; then compounds 4 and 3 (each within the scatter of the next); then compound 2.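

In this assay, going by these compounds alone, hydrogen in place of methyl on a saturated chain carbon bound to an aromatic carbon and a saturated chain carbon gives a number 12 percentage points lower from compound 2 to compound 4 (beyond the scatter) as a modest step, the first direct reading of this change. Trifluoromethyl in place of cyano on an aromatic carbon gives a number 35 percentage points higher from compound 1 to compound 4 (beyond the scatter) as a large step, so 2-carboxyethyl does not by itself fix the number near that of compound 1. Nothing available explains either step.

From the compounds shown here alone, the size of the methyl step with cyano in place of trifluoromethyl remains open. So does the outcome with ethyl or hydroxyl in place of that methyl.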